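This account rests on a few compounds, and the source may have more. Where it says the series, first, only, none or still open, it means among the compounds named here.

Measured compounds:
Compound 1, `CCN(CC)c1ccc(-c2cc(Cl)cn3c([N+](=O)[O-])c(CS(=O)(=O)c4ccccc4)nc23)cc1`. In an ADME assay on HepG2 cells (Homo sapiens) for cytotoxicity, read by MTT assay, with a stated time of 72 h (on this read-out higher numbers stand for lower toxicity in this test and lower numbers for higher toxicity in this test), compound 1 gives > 15600 nM, a limit of the assay rather than a number.
Compound 2, `O=[N+]([O-])c1c(CS(=O)(=O)c2ccccc2)nc2c(-c3ccc(F)cc3)cc(Cl)cn12`. In this assay compound 2 gives > 15600 nM, again a limit.

Compound 2 thus stands at the limit, as do both values shown (the limit of > 15600 nM in this assay, at which 2 of the 2 values shown sit). The step that the two limits leave unreadable from compound 1 to compound 2 is not readable. Compound 3, `O=[N+]([O-])c1c(CS(=O)(=O)c2ccccc2)nc2c(-c3ccco3)cc(Cl)cn12`, differs from compound 2 by furan-2-yl in place of 4-fluorophenyl on an aromatic carbon. Within the data shown here, no measured step bears readably on this change, so no step beyond the scatter is expected. Compound 3 is expected to give 15600 nM in this assay, estimated range 5000 nM to 50000 nM. The expected step is a number no higher from compound 2 to compound 3 (the limit leaves the size open).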

Compound 3, half-maximal cytotoxic concentration: > 3900 nM
Compound 3 was reported as a limit; the forecaster's own chance of this, stated with the estimate: 70%; the middle value is on the limit's open side.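

In this assay compound 3 gives > 3900 nM, a limit, so no step can be read from compound 1 or compound 2 to compound 3, nor between those two. The compounds shown leave open whether furan-2-yl, 4-fluorophenyl and 4-(diethylamino)phenyl differ at all in this assay.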